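Oxadiazole to tert-butyl thiadiazole on compound 2

This account rests on a few compounds, and the source may have more. Where it says the series, first, only, none or still open, it means among the compounds named here.

Three compounds carry numbers in an assay on microsomes from liver for inhibition of acyl-CoA desaturase 1 (Rattus norvegicus); a higher number here means a weaker inhibitor, a lower number a stronger inhibitor. Compound 2 `FC(F)(F)c1ccccc1OC1CCN(c2ccc(-c3nnco3)nn2)CC1` gives 22 nM, the lowest of the three. Compound 1 `FC(F)(F)c1ccc(OC2CCN(c3ccc(-n4ccnc4)nn3)CC2)cc1` gives 371 nM and compound 3 `COc1ccccc1OC1CCN(c2ccc(-n3ccnc3)nn2)CC1` gives 543 nM; both lie beyond the scatter above compound 2. Compound 4 `CC(C)(C)c1nnc(-c2ccc(N3CCC(Oc4ccccc4C(F)(F)F)CC3)nn2)s1` is not yet measured. It differs from compound 2 in one place: 5-(tert-butyl)-1,3,4-thiadiazol-2-yl in place of 1,3,4-oxadiazol-2-yl on an aromatic carbon. Among the compounds with values here, no measured pair shows this kind of change, so the size of the step in this assay cannot be read from the data. The expected step is a 1.8-fold higher number from compound 2 to compound 4 (0.26 log units; within the scatter), a small rise in the number that is not clearly beyond the scatter. Compound 4 is estimated at 40 nM, within a range of 8 nM to 200 nM.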

Compound 4, half-maximal inhibitory concentration: 710 nM
The estimate for compound 4 lay 18-fold (1.25 log units) below the measured number; measured number above the stated range.
By their numbers in this assay, from the lowest: compound 2; then compounds 1, 3 and 4 (each within the scatter of the next).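

In this assay, 5-(tert-butyl)-1,3,4-thiadiazol-2-yl in place of 1,3,4-oxadiazol-2-yl gives a 32-fold higher number from compound 2 to compound 4 (1.51 log units; beyond the scatter), so this position does not accept every five-membered aromatic ring with 3 hetero atoms. The step joins two differences, ring oxygen to sulfur and the added tert-butyl, and their shares cannot be read apart. Nothing measured here accounts for the step.

Still open, as far as these compounds go, is how the unsubstituted 1,3,4-thiadiazol-2-yl would stand in this assay. The same holds for 1,3,4-oxadiazol-2-yl carrying a methyl or tert-butyl group.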